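Swapping fluorine for methyl on a cyclopropyl amide

This account rests on a few compounds, and the source may have more. Where it says the series, first, only, none or still open, it means among the compounds named here.

Of the compounds shown here, three have been measured in an assay on CHO cells for displacement of a labelled ligand from Neuronal acetylcholine receptor; alpha3/alpha6/beta2/beta3 (Homo sapiens), read by scintillation counting; a higher number here means a weaker inhibitor, a lower number a stronger inhibitor. Compound 1 `O=C(C1CC1)N1CC2CC1CN2` gives 10000 nM, compound 2 `O=C(CC1C=CCC1)N1CC2CC(C1)N2` gives 2500 nM, and compound 3 `O=C([C@H]1C[C@H]1F)N1CC2CC(C1)N2` gives 27 nM. Compound 3 thus carries the lowest number of the three; its nearest neighbour is compound 2, whose value lies well beyond the usual scatter, and compound 1 stands further away still. No two of these compounds differ in a single place, so no isolated step can be read from them.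

Compound 4 `C[C@@H]1C[C@H]1C(=O)N1CC2CC(C1)N2` differs from compound 3 in one place: 2-methylcyclopropyl in place of 2-fluorocyclopropyl on a carbonyl carbon. Among the measured compounds shown here, no measured pair isolates such an exchange, so the size of the change in this assay can only be judged loosely. The account expects compound 4 to retain much, though not all, of the strength of compound 3, since compound 3 sets the low mark at 27 nM. Compound 4 is therefore estimated at 80 nM, with a range from 20 nM to 400 nM. This estimate corresponds to an expected step of a 3.0-fold higher number from compound 3 to compound 4 (0.47 log units; beyond the scatter), a modest loss rather than a collapse.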

Compound 4, inhibition constant: 14 nM
Compound 4: middle estimate off by 5.7-fold (0.76 log units), on the high side; the whole stated range lies above it.
By their numbers in this assay, from the lowest: compounds 4 and 3 (each within the scatter of the next); then compound 2; then compound 1.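

In this assay, the exchange of 2-fluorocyclopropyl for 2-methylcyclopropyl on a carbonyl carbon gives a 1.9-fold lower number from compound 3 to compound 4 (0.29 log units; within the scatter) and so leaves the reading within the usual scatter. This pair shows that, on this core and at this position, the fluorine of compound 3 is not needed for a value of this order, since compound 4, with carbon alone in that group of the same size, reads 14 nM. No measurement at hand bears on why the two groups read alike.

The compounds shown leave open how a plain cyclopropyl, a 2-chlorocyclopropyl or a 2-ethylcyclopropyl would read on the core of compound 3. They also leave open whether the opposite arrangement at the two defined stereocentres would hold such a value.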